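This account rests on a few compounds, and the source may have more. Where it says the series, first, only, none or still open, it means among the compounds named here.

Compound 1 `Cc1ccc(Nc2nc(SCc3cn(CC(=O)NC(=O)Nc4ccccn4)nn3)nc(-c3ccc(C(C)C)cc3)c2C#N)cc1` gives > 64000 nM in an ADME assay on GES1 cells (Homo sapiens) for inhibition, read by MTT assay, with a stated time of 72 h (a lower number here means a stronger inhibitor, a higher number a weaker inhibitor), which is a limit rather than a number.
Compound 2 `Cc1ccc(-c2nc(SCc3cn(CC(=O)NC(=O)Nc4ccccn4)nn3)nc(Nc3ccc(C(C)C)cc3)c2C#N)cc1` gives > 64000 nM in this assay, also a limit and not a number.

Compound 2 thus sits where the assay stops reporting numbers, and so does everything measured so far: the limit of > 64000 nM in this assay, at which 2 of the 2 values shown sit. Compound 3 `COc1ccccc1Nc1nc(SCc2cn(CC(=O)NC(=O)Nc3ccccn3)nn2)nc(-c2ccc(C)cc2)c1C#N` carries one change, (2-methoxyphenyl in place of 4-isopropylphenyl on a nitrogen on an aromatic ring). Going by the values given here, no measured pair shows what such a swap does in this assay, so no step beyond the scatter is expected. The expected step is a step that the limit leaves unreadable from compound 2 to compound 3. Compound 3 is therefore estimated at 80000 nM, with a range from 20000 nM to 300000 nM, and most likely the assay would again report only a limit.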

Compound 3, half-maximal inhibitory concentration: > 64000 nM
Compound 3: no number, only a limit (the forecaster's own chance of this, stated with the estimate: 80%); the middle value does not contradict the limit.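

Compound 2 and compound 3 both give a limit rather than a number, so no step between them can be read: the limit of > 64000 nM in this assay, at which 3 of the 3 values shown sit.

The compounds shown leave open what concentration of any of them would reach half-maximal inhibition in this assay, and whether 2-methoxyphenyl in place of 4-isopropylphenyl changes it.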